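This account rests on a few compounds, and the source may have more. Where it says the series, first, only, none or still open, it means among the compounds named here.

Measured compounds and values:
- Compound 1 `O=c1ccn(COC(CO)CO)c(=O)[nH]1` — > 100000 nM
- Compound 2 `Nc1cn(COC(CO)CO)c(=O)[nH]c1=O` — > 100000 nM

Both values come from a functional assay on HeLa cells (Homo sapiens) for inhibition, read by MTT assay, with a stated time of 72 h; a higher number here means a weaker inhibitor, a lower number a stronger inhibitor. For compound 1 the value > 100000 nM is a limit of the assay, not a number. For compound 2 the value > 100000 nM is likewise a limit. Compound 2 therefore stands only at a limit, and the step that the two limits leave unreadable from compound 1 to compound 2 cannot be read in size; both values sit at the limit of > 100000 nM in this assay, at which 2 of the 2 values shown sit.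

Compound 3 `O=C(CCl)Nc1cn(COC(CO)CO)c(=O)[nH]c1=O` differs from compound 2 by (chloromethyl)carbonyl in place of hydrogen on a nitrogen on an aromatic ring. Among the compounds with values here, no measured step describes this kind of change, and the one measured step is itself unreadable, so there is no guide to its direction or size. The expectation for compound 3 is a step of an at least 1.6-fold lower number from compound 2 to compound 3 (0.22 log units; that floor lies within the scatter) from compound 2, with wide uncertainty. Compound 3 is estimated at 60000 nM in this assay, in a range from 8000 nM to 300000 nM, with a real chance that only a limit is reported again.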

Compound 3, half-maximal inhibitory concentration: 12000 nM
For compound 3 the middle estimate is 5.0-fold (0.70 log units) above the measured one; the measured number falls inside the stated range.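

Within the data shown here, with (chloromethyl)carbonyl in place of hydrogen on the amino nitrogen, this assay gives a number rather than a limit for the first time: an at least 8.3-fold lower number from compound 2 to compound 3 (0.92 log units; beyond the scatter). Set against the core without the amino group, ((chloromethyl)carbonyl)amino in place of hydrogen on an aromatic carbon gives an at least 8.3-fold lower number from compound 1 to compound 3 (0.92 log units; beyond the scatter). Both steps are floors, since each starts from a compound that stands only at a limit, and the step between those two starting compounds cannot be read: the limit of > 100000 nM in this assay, at which 2 of the 3 values shown sit.

The compounds shown leave open whether the chlorine or the carbonyl carries this step, and an acetyl group, with hydrogen where the chlorine stands, would separate the two. On these data alone, how a longer chain in place of the chloromethyl part would read in this assay also stays open.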